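The compounds below may be only part of what the source reports. "The series", "measured", "known", "first", "only" and "open" are said of these compounds alone.

Measured compounds:
- compound 1, `O=C(/C=C\Nc1ccc2cc[nH]c2c1)c1nc(-c2ccc(C(F)(F)F)cc2)n2ccccc12`: in a functional assay on MDA-MB-231 cells (Homo sapiens) for cytotoxicity, read by MTT assay, with a stated time of 48 h (on this read-out lower numbers stand for stronger inhibition and higher numbers for weaker inhibition), compound 1 reaches only the assay limit, > 30000 nM.
- compound 2, `O=C(/C=C\Nc1ccc2[nH]ccc2c1)c1nc(-c2ccc(C(F)(F)F)cc2)n2ccccc12`: in this assay compound 2 gives 1180 nM.
- compound 3, `O=C(/C=C\Nc1ccc(Cl)cc1)c1nc(-c2ccc(C(F)(F)F)cc2)n2ccccc12`: in this assay compound 3 gives 3840 nM.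

Compound 3 holds the highest of the two numbers; its nearest neighbour is compound 2, with a 3.3-fold higher number from compound 2 to compound 3 (0.51 log units; beyond the scatter). Compound 1 sits at a limit, (the limit of > 30000 nM in this assay, at which 1 of the 3 values shown sits). The other measured steps, an at least 25-fold lower number from compound 1 to compound 2 (1.40 log units; beyond the scatter) and an at least 7.8-fold lower number from compound 1 to compound 3 (0.89 log units; beyond the scatter), change the whole aryl group on the amine nitrogen.

Compound 4, `O=C(/C=C\Nc1ccc(F)cc1)c1nc(-c2ccc(C(F)(F)F)cc2)n2ccccc12`, differs from compound 3 only by fluoro in place of chloro on an aromatic carbon. Among the measured compounds shown here, no measured step swaps one halogen for another on this ring; all three steps change a larger group on the amine nitrogen and so do not bear on a single-atom exchange. With no evidence either way, compound 4 is expected to stay within the scatter of compound 3, and the estimated step is a 1.3-fold higher number from compound 3 to compound 4 (0.11 log units; within the scatter). In this assay compound 4 is therefore estimated at 5000 nM, with a range from 1800 nM to 15000 nM.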

Compound 4, half-maximal inhibitory concentration: > 30000 nM
Compound 4: a limit, no number; the forecaster's own chance of this, stated with the estimate: 10%; middle value at least 6.0-fold (0.77 log units) away from the limit.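

In this assay, fluoro in place of chloro gives an at least 7.8-fold higher number from compound 3 to compound 4 (0.89 log units; beyond the scatter), so at this aromatic carbon, para to a large group, an exchange of a single atom is enough to reach the top of the readable range. Set against the 1H-indol-5-yl compound, 4-fluorophenyl gives an at least 25-fold higher number from compound 2 to compound 4 (1.40 log units; beyond the scatter), while 4-chlorophenyl gave only a 3.3-fold higher number from compound 2 to compound 3 (0.51 log units; beyond the scatter), so the choice of halogen decides how the 4-halophenyl group compares with that indolyl group. Compound 4 reaches only a limit of the assay, which it shares with compound 1: the limit of > 30000 nM in this assay, at which 2 of the 4 values shown sit.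

From the compounds shown here alone, the step from compound 1 to compound 4 cannot be read, so the order of these two stays open. Also open, going by these compounds, is whether chloro or fluoro is the exception here: bromo, methoxy or a plain phenyl at this position would separate the two cases.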